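The source may hold more compounds than are shown below. What is called first, only, known or untested is meant among the compounds shown, and "the series" means these compounds.

In a functional assay on ZR-75-1 cells (Homo sapiens) for inhibition, read by sulforhodamine B assay (on this read-out lower numbers stand for stronger inhibition of growth and higher numbers for weaker inhibition of growth), the series reads:
- compound 1 `c1ccc(-c2ccc(-c3ccc(-c4nc5ccccc5[nH]4)cc3)cc2)cc1` gives 100000 nM as its value
- compound 2 `COc1ccc(-c2ccc(-c3ccc(-c4nc5ccccc5[nH]4)cc3)cc2)cc1` gives 35100 nM as its value

Compound 2 holds the lower of these two numbers, and the gap to compound 1 lies beyond the scatter. Compound 3 `Clc1cccc(-c2ccc(-c3ccc(-c4nc5ccccc5[nH]4)cc3)cc2)c1` has not yet been measured. Its difference from compound 2 is 3-chlorophenyl in place of 4-methoxyphenyl on an aromatic carbon and it sits on the same core, para to a large group.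

Among the measured compounds shown here, only one measured step bears on this change. That step is a 2.8-fold lower number from compound 1 to compound 2 (0.45 log units; beyond the scatter) for methoxy in place of hydrogen on an aromatic carbon, and it is modest in size. For the measured compounds named here, compound 3 gives up that methoxy, and no measured compound carries 3-chlorophenyl, so the data offer only weak guidance on the new group. In this assay a small move toward a higher number is expected, no larger than the measured step and possibly within the scatter. The estimate amounts to a 1.4-fold higher number from compound 2 to compound 3 (0.15 log units; within the scatter) as the expected step. For compound 3 the estimated value is 50000 nM with an expected range from 15000 nM to 100000 nM in this series.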

Compound 3, concentration for 50% growth inhibition: 41200 nM
The estimate for compound 3 lay 1.2-fold (0.08 log units) above the measured number, within the range that was stated.
By their numbers in this assay, from the lowest: compounds 2 and 3 (each within the scatter of the next); then compound 1.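

In this assay, the change to 3-chlorophenyl in place of 4-methoxyphenyl gives a 1.2-fold higher number from compound 2 to compound 3 (0.07 log units; within the scatter), so compound 2 and compound 3 cannot be told apart here and the methoxy group is not required to hold this level, even though the entering group counts no hydrogen-bond acceptor. Chloro in place of hydrogen on an aromatic carbon gives a 2.4-fold lower number from compound 1 to compound 3 (0.39 log units; beyond the scatter), which sits alongside a 2.8-fold lower number from compound 1 to compound 2 (0.45 log units; beyond the scatter) and shows that, at this end of the molecule, a departure from the unsubstituted compound 1 beyond the scatter is not unique to methoxy. No measured information on the reason for these steps is available.

The names 4-methoxyphenyl and 3-chlorophenyl differ in both the group and its number, so the compounds shown cannot separate the contribution of the substituent from that of its place on the ring. On these data alone, whether an amine or a carboxylic acid on this ring would move the number further than methoxy or chloro also remains open.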